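Methoxy in Place of Amino on a Sulfonamide Aryl Ring

This account rests on a few compounds, and the source may have more. Where it says the series, first, only, none or still open, it means among the compounds named here.

Compound 1 `CC1CCN(C2CCN(S(=O)(=O)c3cccc(N)c3)CC2)CC1` stands with the highest number of the two measured compounds in a functional assay on DLD-1 cells (Homo sapiens) for antiproliferative activity, read by CellTiter-Glo, with a stated time of 72 h (a lower number here means a stronger inhibitor, a higher number a weaker inhibitor), where compound 1 gives 3400 nM. Its nearest neighbour, compound 2 `COc1ccc(NS(=O)(=O)N2CCC(N3CCC(C)CC3)CC2)cc1`, gives 814 nM in this assay, a gap that lies beyond the scatter of the measurement. Compound 3 `COc1cccc(S(=O)(=O)N2CCC(N3CCC(C)CC3)CC2)c1` has not yet been measured. It differs from compound 1 in one place: methoxy in place of amino on an aromatic carbon. Going by the values given here, no pair of measured compounds shows this change on its own, so no measured step can guide the expectation directly. Compound 2 carries a methoxy group on its aryl ring and shows the lower number, but its linker also differs, so that comparison is only loose. A small improvement is expected for the step of a 1.7-fold lower number from compound 1 to compound 3 (0.23 log units; within the scatter), though a result within the scatter would not surprise. Compound 3 is therefore estimated at 2000 nM, with a range from 600 nM to 6500 nM.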

Compound 3, half-maximal inhibitory concentration: > 5000 nM
Compound 3 gave a limit, no number; the forecaster's own chance of this, stated with the estimate: 5%; middle value at least 2.5-fold (0.39 log units) away from the limit.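

In this assay compound 3 gives > 5000 nM, which is a limit of the assay and not a number. Methoxy in place of amino on this aromatic carbon, the first such change that can be read on its own, gives an at least 1.4-fold higher number from compound 1 to compound 3 (0.16 log units; that floor lies within the scatter), so the step shows no gain in potency at this position. How far compound 3 really lies from compound 1 cannot be told, and the result ends at a limit: the limit of > 5000 nM in this assay, at which 1 of the 3 values shown sits.

The compounds shown leave open whether the amino group itself matters at this carbon or whether methoxy is simply a poor replacement for it. A hydroxyl group, a methyl group or an acetamide at the same place would bear on that question, as would a methoxy group on another carbon of the aromatic ring.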